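Oxime to hydrazone on the shared core: compound 4

A few compounds are considered here, and "the series" means these few. Any claim that something is new, unique, unknown or untested is made for them only; others in the source may bear on it.

Compound 3 `OC[C@H]1OC(n2c(Cl)c(/C=N/O)c3cc(Cl)c(Cl)cc32)[C@H](O)[C@@H]1O` gives the lowest of the two numbers in hand in a functional assay on KB cells (Homo sapiens) for cytotoxicity, read by spectrophotometry and crystal violet staining (a higher number here means a weaker inhibitor, a lower number a stronger inhibitor), where compound 3 gives 25000 nM. Compound 1 `N#Cc1c(Cl)n(C2O[C@H](CO)[C@@H](O)[C@H]2O)c2cc(Cl)c(Cl)cc12` gives 65000 nM in this assay. Compound 2 `N/C(=N\O)c1c(Cl)n(C2O[C@H](CO)[C@@H](O)[C@H]2O)c2cc(Cl)c(Cl)cc12` reaches only a limit of this assay, (the limit of > 100000 nM in this assay, at which 1 of the 3 values shown sits), where compound 2 gives > 100000 nM. The measured steps are a 2.6-fold lower number from compound 1 to compound 3 (0.41 log units; beyond the scatter) and an at least 4.0-fold lower number from compound 2 to compound 3 (0.60 log units; beyond the scatter); the step of an at least 1.5-fold higher number from compound 1 to compound 2 (0.18 log units; that floor lies within the scatter) stays within the scatter.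

Compound 4 `CN(C)/N=C/c1c(Cl)n(C2O[C@H](CO)[C@@H](O)[C@H]2O)c2cc(Cl)c(Cl)cc12` differs from compound 3 by dimethylamino in place of hydroxy on a double-bonded nitrogen. For the measured compounds named here, all three measured steps exchange the group on an aromatic carbon; none of them touches the substituent on the double-bonded nitrogen, so no step bears directly on this change. What the series does show is that compound 3 holds the lowest number, so a move away from its oxime has more room to raise the number than to lower it. Going by the values given here, a modest loss is therefore expected for compound 4, a step of a 2.0-fold higher number from compound 3 to compound 4 (0.30 log units; within the scatter) in this assay, with wide uncertainty since the change has no measured precedent here. The expected value for compound 4 is 50000 nM, with a range from 15000 nM to 150000 nM.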

Compound 4, half-maximal inhibitory concentration: 70000 nM
Estimate against measurement, compound 4: 1.4-fold (0.15 log units) below; the measured number falls inside the stated range.
By their numbers in this assay, from the lowest: compound 3; then compounds 1 and 4 (each within the scatter of the next). At a limit, above all of these: compound 2.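

The first change shown on the double-bonded nitrogen shows that this substituent matters in this assay: with dimethylamino in place of hydroxy there is a 2.8-fold higher number from compound 3 to compound 4 (0.45 log units; beyond the scatter), which leaves the oxime of compound 3 with the lowest number of the series. Against the nitrile, the dimethylamino compound shows a 1.1-fold higher number from compound 1 to compound 4 (0.03 log units; within the scatter), so the two cannot be ordered, and against the amidoxime there is an at least 1.4-fold lower number from compound 2 to compound 4 (0.15 log units; that floor lies within the scatter), a floor set by the limit of compound 2 that gives no order either. Nothing measured here accounts for the step from hydroxy to dimethylamino.

The exchange alters size and hydrogen-bond donor count together, so the compounds shown cannot separate the two; methoxy on the same nitrogen would keep the oxygen without the donor, and amino or methylamino would keep the nitrogen with a smaller group. On these data alone, whether any group on this nitrogen can bring the number below that of compound 3 stays open, as does whether the ranking of these groups holds on a core with other substituents.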